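A few compounds are considered here, and "the series" means these few. Any claim that something is new, unique, unknown or untested is made for them only; others in the source may bear on it.

Compound 1 `CCn1cc(C(=O)O)c(=O)c2cc(F)c(N3CCN(C(=N)NS(=O)(=O)c4ccc(C)cc4)CC3)cc21` was examined in a functional assay on HeLa cells (Homo sapiens) for antiproliferative activity, read by MTT assay, with a stated time of 72 h (on this read-out higher numbers stand for weaker inhibition and lower numbers for stronger inhibition), where compound 1 gives 32 nM. Compound 2 `N=C(NS(=O)(=O)c1ccc(C(F)(F)F)cc1)N1CCN(c2cc3c(cc2F)c(=O)c(C(=O)O)cn3C2CC2)CC1` differs from compound 1 in more than one place, and in this assay compound 2 gives 32 nM; the two values are level at the digits printed, within the scatter, so neither can be called the more active. Compound 3 `CCn1cc(C(=O)O)c(=O)c2cc(F)c(N3CCN(C(=N)NS(=O)(=O)c4ccccc4Cl)CC3)cc21` has not yet been measured in this assay. Its difference from compound 1 is confined to one place: 2-chlorophenyl in place of 4-methylphenyl on a sulfonyl sulfur. Among the measured compounds shown here, no measured pair differs only there, so the size of this step is not known from the data. Since compound 2, which also carries a different group on the sulfonyl sulfur among its other changes, gives 32 nM, level with compound 1, the step from compound 1 to compound 3 is expected to be small, estimated as a 1.3-fold higher number from compound 1 to compound 3 (0.10 log units; within the scatter). Compound 3 is therefore expected to give about 40 nM, with a range from 15 nM to 110 nM.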

Compound 3, half-maximal inhibitory concentration: 32 nM
Compound 3: the middle estimate sits 1.3-fold (0.10 log units) above what was measured; the measured number falls inside the stated range.
By their numbers in this assay, from the lowest: compounds 1, 2 and 3 (each within the scatter of the next).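

In this assay, 2-chlorophenyl in place of 4-methylphenyl on a sulfonyl sulfur gives no change at the digits printed from compound 1 to compound 3 (within the scatter). Among the compounds shown here, this is the first reading of a change at this position with the rest of the molecule held fixed, as compound 2 differs from compound 1 in more than one place. It shows that this one exchange of aryl groups, which also replaces a methyl with a chlorine, leaves the read-out unmoved, while no measured property of either group is available to account for that.

The compounds shown leave open whether the position stays this flat with something other than a substituted phenyl on the sulfonyl sulfur, such as a methyl group, a longer alkyl chain or a pyridine ring. They also leave open what an amine or a nitrile on the phenyl ring would give.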